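The compounds below may be only part of what the source reports. "The series", "measured", "known", "first", "only" and "open" are said of these compounds alone.

The compounds measured so far in an ADME assay on liver (Homo sapiens) for metabolic stability, read by LC-MS, using microsomes and NADPH; a higher number here means that more of the compound is left, a lower number that less of the compound is left:

Compound 1, `CCCN(Cc1ccc(OCCN2C(=O)CCC2=O)c(C)c1)C(CC(=O)O)c1ccc(Cl)cc1`, gives 85%
Compound 2, `Cc1cc(CN(CC2CC2)C(CC(=O)O)c2ccc(Cl)cc2)ccc1OCCN1C(=O)CCC1=O`, gives 96%
Compound 3, `CCCN(Cc1ccc(OCCn2c(=O)ccn(C)c2=O)c(OC)c1)C(CC(=O)O)c1ccc(Cl)cc1`, gives 61%

Compound 1 and compound 2 share one core and differ by a single change: cyclopropyl in place of ethyl on a saturated chain carbon bound to an amine nitrogen. That change produced a number 11 percentage points higher from compound 1 to compound 2 (beyond the scatter). Compound 3 sits on a different core; the difference between the two cores is not broken down here. Its value is the lowest of the three, and its gaps to compound 1 and to compound 2 both lie beyond the scatter.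

Compound 4, `COc1cc(CN(CC2CC2)C(CC(=O)O)c2ccc(Cl)cc2)ccc1OCCn1c(=O)ccn(C)c1=O`, has not yet been measured in this assay. It differs from compound 3 by cyclopropyl in place of ethyl on a saturated chain carbon bound to an amine nitrogen, which is the same change, at the same place, as that between compound 1 and compound 2. Because that pair gave a number 11 percentage points higher from compound 1 to compound 2 (beyond the scatter), a rise of similar size is expected here too, though it rests on a single pair on another core. The expected step is a number 10 percentage points higher from compound 3 to compound 4 (within the scatter). Compound 4 is therefore estimated to give about 71%, most likely between 56% and 86%.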

Compound 4, percent of the compound remaining: 55%
Compound 4: middle estimate off by 16 percentage points, on the high side; the whole stated range lies above it.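

In this assay cyclopropyl in place of ethyl on a saturated chain carbon bound to an amine nitrogen gave a number 6 percentage points lower from compound 3 to compound 4 (within the scatter) and so did not repeat on this core the rise seen on the core of compound 1. The change therefore cannot be treated as a fixed increment that travels from one core to the other: the same change on two cores in this assay, a number 11 percentage points higher (beyond the scatter) from compound 1 to compound 2 and a number 6 percentage points lower (within the scatter) from compound 3 to compound 4, 17 percentage points apart, beyond the scatter of two such steps. This comparison rests on one pair per core, so it does not show which feature of the cores separates the two outcomes, and it does not establish a fall on the core of compound 3, where the step stays within the scatter.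

The compounds shown include no pair whose cores differ in one place only, which leaves the source of the contrast unresolved. On these data alone, it also remains open how a cyclobutyl group or a longer chain on the same saturated chain carbon would read on either core.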